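This account rests on a few compounds, and the source may have more. Where it says the series, first, only, none or still open, it means among the compounds named here.

Series on the shared core of compound 1 `CNCC(=O)N1N=C(c2cc3ccccc3oc2=O)CC1c1ccccc1`, varied only at the amine substituent. In a functional assay on PC-3 cells (Homo sapiens) for cytotoxicity, read by MTT assay, with a stated time of 48 h (a higher number here means a weaker inhibitor, a lower number a stronger inhibitor), compound 1 gives 2300 nM. Among the measured compounds shown here, compound 2 `CCCNCC(=O)N1N=C(c2cc3ccccc3oc2=O)CC1c1ccccc1` gives 7270 nM, the highest of the two numbers so far; the step of a 3.2-fold higher number from compound 1 to compound 2 (0.50 log units; beyond the scatter) is the only measured step in the set. Compound 3 `CC(C)CNCC(=O)N1N=C(c2cc3ccccc3oc2=O)CC1c1ccccc1` differs from compound 2 by methyl in place of hydrogen on a saturated chain carbon bound to two saturated chain carbons, the same kind of homologation one bond further out than the change from compound 1 to compound 2. For the measured compounds named here, only that one step bears on it, and loosely, since its change sits on the carbon bound to the amine nitrogen rather than on a carbon bound to two saturated chain carbons. That step raised the number modestly; a branch one carbon out may do the same to a lesser degree, or nothing beyond the scatter. Compound 3 is thus expected at 9000 nM (range 3500 nM to 25000 nM), an expected step of a 1.2-fold higher number from compound 2 to compound 3 (0.09 log units; within the scatter) in this assay.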

Compound 3, half-maximal inhibitory concentration: 1920 nM
Beside the measured number, compound 3's estimate is 4.7-fold (0.67 log units) above it, and the stated range ends above it.
By their numbers in this assay, from the lowest: compounds 3 and 1 (each within the scatter of the next); then compound 2.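

In this assay, the branch reverses the earlier rise rather than extending it: methyl in place of hydrogen on a saturated chain carbon bound to two saturated chain carbons gives a 3.8-fold lower number from compound 2 to compound 3 (0.58 log units; beyond the scatter). Against the methyl compound, the isobutyl group gives a 1.2-fold lower number from compound 1 to compound 3 (0.08 log units; within the scatter), so the larger substituent carries no measurable penalty here, and adding carbon to the amine substituent does not order the numbers across these three compounds, with compound 2 standing apart from compound 1 and compound 3. No supporting data bear on why the propyl and isobutyl groups differ.

Going by these compounds, whether the higher number of compound 2 is peculiar to the straight propyl chain remains open, and a butyl chain or an isopropyl group on the amine would test this. On these data alone, a cyclic amine such as morpholine, or a hydroxyethyl chain, also remains untested.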